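A few compounds are considered here, and "the series" means these few. Any claim that something is new, unique, unknown or untested is made for them only; others in the source may bear on it.

Working notes on the series.

Compound 1 `CC/N=C(\S)NCCCCCn1nc(-c2ccccc2)ccc1=O` carries the longer chain and the thiourea-type end group; in a functional assay on the whole organism with Rattus norvegicus as the target, at a dose of 100 mg/kg (on this read-out lower numbers stand for less inhibition and higher numbers for more inhibition at the one dose given (going by the name of the read-out)), compound 1 gives 66.4%. Compound 2 `CCC/N=C(/NC#N)NCCCCCn1nc(-c2ccccc2)ccc1=O` has the cyanoguanidine-type end group on the same chain, and in this assay compound 2 gives 27.5%. The change from compound 2 to compound 1 is a group of 5 heavy atoms (3 carbon, 1 nitrogen, 1 sulfur; no ring) in place of a group of 8 heavy atoms (5 carbon, 3 nitrogen; no ring), on an amine nitrogen, and the step of a number 38.9 percentage points higher from compound 2 to compound 1 (beyond the scatter).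

Compound 3 `CCC/N=C(/NC#N)NCCCn1nc(-c2ccccc2)ccc1=O` has the shorter chain; in this assay compound 3 gives 52.9%. The difference between the core of compound 3 and the core of compound 2 is not broken down here.

Compound 4 `CC/N=C(\S)NCCCn1nc(-c2ccccc2)ccc1=O` is not yet measured. From compound 3 it differs by a group of 5 heavy atoms (3 carbon, 1 nitrogen, 1 sulfur; no ring) in place of a group of 8 heavy atoms (5 carbon, 3 nitrogen; no ring), on an amine nitrogen, the same change at the same place as from compound 2 to compound 1. Because a number 38.9 percentage points higher from compound 2 to compound 1 (beyond the scatter), a step of similar direction is expected, tempered by the ceiling of the read-out: the step expected is a number 27.1 percentage points higher from compound 3 to compound 4 (beyond the scatter). Compound 4 is estimated at 80% in this assay, within 60% to 95%.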

Compound 4, a percentage reported as inhibition, in the whole organism at one dose (the size of the read-out at that dose, not a potency): 39%
Beside the measured number, compound 4's estimate is 41 percentage points above it, outside the stated range (below it).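

In this assay, exchanging the end group on the shorter chain gives a number 13.9 percentage points lower from compound 3 to compound 4 (beyond the scatter), so the change does not carry over from the longer chain in direction or size: the same change on two cores in this assay, a number 38.9 percentage points higher (beyond the scatter) from compound 2 to compound 1 and a number 13.9 percentage points lower (beyond the scatter) from compound 3 to compound 4, 52.8 percentage points apart, beyond the scatter of two such steps

With the sulfur-bearing end group kept, the shorter chain goes with a number 27.4 percentage points lower from compound 1 to compound 4 (beyond the scatter). These two pairs, read at one dose, show that the result of the exchange depends on the core, but they do not show why, or how it would behave on any other core.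

Left open is how the exchange behaves on a chain longer than either of these or on one of intermediate length. Also open, going by these compounds, is whether other end groups, such as a urea or an amide, follow either pattern.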